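Swapping the aryl group on silicon: a thiol variant

The source may hold more compounds than are shown below. What is called first, only, known or untested is meant among the compounds shown, and "the series" means these compounds.

Measured compounds:
- compound 1, `CCN(C/C=C/C#CC(C)(C)C)Cc1cccc(OC[Si](C)(C)c2ccc(F)cc2)c1`: in a functional assay on liver (Sus scrofa) for inhibition of squalene monooxygenase (Homo sapiens), using microsomes (a higher number here means a weaker inhibitor, a lower number a stronger inhibitor), compound 1 gives 60 nM
- compound 2, `CCN(C/C=C/C#CC(C)(C)C)Cc1cccc(OC[Si](C)(C)c2ccc(OC)cc2)c1`: in this assay compound 2 gives 870 nM
- compound 3, `CCN(C/C=C/C#CC(C)(C)C)Cc1cccc(OC[Si](C)(C)c2ccccc2C)c1`: in this assay compound 3 gives 30 nM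

Within the data shown here, compound 3 has the lowest number of the three in this assay, but the step of a 2.0-fold lower number from compound 1 to compound 3 (0.30 log units; within the scatter) lies within the scatter, so only the step of a 29-fold lower number from compound 2 to compound 3 (1.46 log units; beyond the scatter) sets it clearly apart. Compound 4 `CCN(C/C=C/C#CC(C)(C)C)Cc1cccc(OC[Si](C)(C)c2ccc(S)cc2)c1` differs from compound 3 by 4-sulfanylphenyl in place of 2-methylphenyl on a silicon. Among the measured compounds shown here, no measured step introduces this group; the only guides are the other swaps of the aryl group on that silicon, a 15-fold higher number from compound 1 to compound 2 (1.16 log units; beyond the scatter) and a 29-fold lower number from compound 2 to compound 3 (1.46 log units; beyond the scatter), both large and in opposite directions. The step of an 8.3-fold higher number from compound 3 to compound 4 (0.92 log units; beyond the scatter) is therefore expected to give a higher number, of moderate size and uncertain. Compound 4 is estimated at 250 nM, with a range from 60 nM to 1000 nM.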

Compound 4, half-maximal inhibitory concentration: 8000 nM
Estimate against measurement, compound 4: 32-fold (1.51 log units) below, outside the stated range (above it).
By their numbers in this assay, from the lowest: compounds 3 and 1 (each within the scatter of the next); then compound 2; then compound 4.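

Among the aromatic-carbon groups shown, sulfanyl gives the weakest inhibition: a 130-fold higher number from compound 1 to compound 4 (2.12 log units; beyond the scatter) for sulfanyl in place of fluoro, and a 9.2-fold higher number from compound 2 to compound 4 (0.96 log units; beyond the scatter) for sulfanyl in place of methoxy. The change of aryl group on silicon can therefore be very costly, even though 2-methylphenyl and 4-sulfanylphenyl have the same heavy-atom count, as a 270-fold higher number from compound 3 to compound 4 (2.43 log units; beyond the scatter) shows. Nothing available explains this loss. On these data alone, it remains open whether a hydroxyl or an amine on the same phenyl ring would behave like sulfanyl, or like fluoro.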